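Chain-terminus variation in a hydroxamic acid series

The compounds below may be only part of what the source reports. "The series", "measured", "known", "first", "only" and "open" are said of these compounds alone.

Measured compounds:
compound 1, `Cc1ccc(OCCCCN(Cc2ccc(C(=O)NO)cc2)c2ncc(-c3ccc(C)cc3)s2)cc1`: 11000 nM
compound 2, `CCCCCCN(Cc1ccc(C(=O)NO)cc1)c1ncc(-c2ccc(C)cc2)s1`: 7420 nM
compound 3, `CCCCCN(Cc1ccc(C(=O)NO)cc1)c1ncc(-c2ccc(C)cc2)s1`: 7020 nM

In a functional assay on HepG2 cells (Homo sapiens) for antiproliferative activity, read by MTT assay, with a stated time of 48 h (on this read-out lower numbers stand for stronger inhibition of growth and higher numbers for weaker inhibition of growth), compound 3 stands at the low end of the three numbers shown; compound 2 lies nearest, compound 1 furthest. The separations are a 1.1-fold lower number from compound 2 to compound 3 (0.02 log units; within the scatter) and a 1.6-fold lower number from compound 1 to compound 3 (0.20 log units; within the scatter), and the remaining pair shows a 1.5-fold lower number from compound 1 to compound 2 (0.17 log units; within the scatter), so the three compounds cannot be told apart on these data.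

Compound 4, `Cc1ccc(-c2cnc(N(CCCCOc3ccccc3)Cc3ccc(C(=O)NO)cc3)s2)cc1`, is the next member. Relative to compound 3 the difference is phenoxy in place of methyl on a saturated chain carbon, four bonds along the chain from a nitrogen on an aromatic ring. The step that bears on it most directly is a 1.6-fold lower number from compound 1 to compound 3 (0.20 log units; within the scatter), which runs the opposite way and exchanges a closely related aryloxy group for methyl; a 1.5-fold lower number from compound 1 to compound 2 (0.17 log units; within the scatter) points the same way. Both steps were small. Reversing the sense of those steps, the change is therefore expected to read a 1.4-fold higher number from compound 3 to compound 4 (0.13 log units; within the scatter), with no shift beyond the scatter anticipated. On that basis compound 4 is estimated at 9500 nM, with a range from 5000 nM to 18000 nM.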

Compound 4, concentration for 50% growth inhibition: 16600 nM
The estimate for compound 4 lay 1.7-fold (0.24 log units) below the measured number, within the range that was stated.
By their numbers in this assay, from the lowest: compounds 3, 2, 1 and 4 (each within the scatter of the next, the first and the last beyond it).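

In this assay, among these compounds, phenoxy in place of methyl gives a 2.4-fold higher number from compound 3 to compound 4 (0.37 log units; beyond the scatter), and phenoxy in place of ethyl at the same chain carbon gives a 2.2-fold higher number from compound 2 to compound 4 (0.35 log units; beyond the scatter); these modest steps are the first at this position to pass the scatter, since the steps from compound 1 to the two alkyl compounds stayed within it. The methyl on the terminal aromatic ring shows no clear effect: hydrogen in its place gives a 1.5-fold higher number from compound 1 to compound 4 (0.18 log units; within the scatter), so compound 1 and compound 4 cannot be told apart. No available measurement bears on the reason for these steps.

From the compounds shown here alone, it remains open whether a terminal amine or carboxylic acid at this chain carbon would read differently from phenoxy. Also open, going by these compounds, is how a longer chain carrying the phenoxy group, or a methoxy or chloro group on its ring, would read.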